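Amino for nitro, made once on each of two cores

The source may hold more compounds than are shown below. What is called first, only, known or untested is meant among the compounds shown, and "the series" means these compounds.

Compound 1 `COc1ccc(NC(=O)c2cc(OC)c(OC)c(OC)c2)cc1[N+](=O)[O-]` and compound 2 `COc1ccc(NC(=O)c2cc(OC)c(OC)c(OC)c2)cc1N` share one core; compound 3 `COc1ccc(OC(=O)c2cc(OC)c(OC)c(OC)c2)cc1[N+](=O)[O-]` and compound 4 `COc1ccc(OC(=O)c2cc(OC)c(OC)c(OC)c2)cc1N` share another. The difference between the two cores is not broken down here.

In a functional assay on HCT-15 cells (Homo sapiens) for antiproliferative activity, read by MTT assay, with a stated time of 72 h (on this read-out higher numbers stand for weaker inhibition and lower numbers for stronger inhibition), compound 1 gives 17600 nM. In this assay compound 2 gives 6500 nM. The step of a 2.7-fold lower number from compound 1 to compound 2 (0.43 log units; beyond the scatter) rests on the change amino in place of nitro on an aromatic carbon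

For compound 3 only a limit is known: in this assay compound 3 gives > 100000 nM, which is a limit of the assay and not a number. This is the limit of > 100000 nM in this assay, at which 1 of the 3 values shown sits.

Compound 4 stands to compound 3 as compound 2 stands to compound 1. The change is amino in place of nitro on an aromatic carbon

The surroundings of the change read the same for both pairs, so this is the same change, occurring twice among the compounds here, with a single measured size, the step from compound 1 to compound 2.

The starting point for compound 4 is open, since the value of compound 3 is a limit. A step of the measured size applied from a number at or beyond that limit would leave compound 4 weak, and a limit reading for compound 4 remains quite possible. From compound 3 the expected step is an at least 1.6-fold lower number from compound 3 to compound 4 (0.22 log units; that floor lies within the scatter). Compound 4 is estimated in this assay at 60000 nM, with a range of 20000 nM to 150000 nM.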

Compound 4, half-maximal inhibitory concentration: > 100000 nM
Compound 4: only a limit was reported; the forecaster's own chance of this, stated with the estimate: 45%; at least 1.6-fold (0.22 log units) between middle value and limit.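

Compound 3 and compound 4 both sit at a limit and not at a number, so the change from nitro to amino on this core gives no readable step in this assay: the limit of > 100000 nM in this assay, at which 2 of the 4 values shown sit.

The compounds shown leave open whether amino in place of nitro on the core of compound 3 has any effect of the size seen on the other core, namely a 2.7-fold lower number from compound 1 to compound 2 (0.43 log units; beyond the scatter).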